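A few compounds are considered here, and "the series" means these few. Any claim that something is new, unique, unknown or untested is made for them only; others in the source may bear on it.

In a functional assay on A-375 cells (Homo sapiens) for cytotoxicity, read by MTT assay (on this read-out higher numbers stand for weaker inhibition and lower numbers for stronger inhibition), compound 1 `C#CCOc1cc(/C=C/C(=O)c2ccc(OC)c3c2OC(C)(C)C=C3)ccc1OC` gives > 10000 nM, which is a limit of the assay and not a number. Compound 2 `CCCCC(=O)Oc1cc(/C=C/C(=O)c2ccc(OC)c3c2OC(C)(C)C=C3)ccc1OC` gives 220 nM, and compound 3 `COc1cccc(C(=O)Oc2cc(/C=C/C(=O)c3ccc(OC)c4c3OC(C)(C)C=C4)ccc2OC)c1` gives 800 nM, the higher of these two numbers. Compound 4 `COc1ccc(/C=C/C(=O)Oc2cc(/C=C/C(=O)c3ccc(OC)c4c3OC(C)(C)C=C4)ccc2OC)cc1` differs from compound 3 by 2-(4-methoxyphenyl)ethenyl in place of 3-methoxyphenyl on a carbonyl carbon, with 2-(4-methoxyphenyl)ethenyl in place of 3-methoxyphenyl on a carbonyl carbon. The closest guide is a 3.6-fold higher number from compound 2 to compound 3 (0.56 log units; beyond the scatter), a modest change at that same carbonyl carbon. The large at least 12-fold lower number from compound 1 to compound 3 (1.09 log units; beyond the scatter) involved losing the carbonyl, which compound 4 keeps, so it bears less directly. No step beyond the scatter is therefore expected, and the estimated step is a 1.2-fold lower number from compound 3 to compound 4 (0.09 log units; within the scatter). For compound 4, the expected value is 650 nM, within an estimated range of 200 nM to 2500 nM.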

Compound 4, half-maximal inhibitory concentration: 2630 nM
Compound 4: the middle estimate sits 4.0-fold (0.61 log units) below what was measured; measured number above the stated range.
By their numbers in this assay, from the lowest: compound 2; then compound 3; then compound 4. At a limit, above all of these: compound 1.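

In this assay, the group on this carbonyl carbon matters even when an aromatic ring is kept, with a 3.3-fold higher number from compound 3 to compound 4 (0.52 log units; beyond the scatter). Against butyl, the same group gives a 12-fold higher number from compound 2 to compound 4 (1.08 log units; beyond the scatter), so among these esters, 2-(4-methoxyphenyl)ethenyl sits at the weak end. Compound 1 stands at a limit, not a number, so an at least 3.8-fold lower number from compound 1 to compound 4 (0.58 log units; beyond the scatter) gives only a minimum size for that step: the limit of > 10000 nM in this assay, at which 1 of the 4 values shown sits.

As far as these compounds go, whether the double bond or the change from 3-methoxyphenyl to a 4-methoxyphenyl group carries the step stays open. From the compounds shown here alone, how an amine or a chain longer than butyl would read on this carbonyl carbon is also open.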